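The compounds below may be only part of what the source reports. "The series", "measured", "known", "first", "only" and "open" are said of these compounds alone.

Measured compounds in an ADME assay on HEL cells (Homo sapiens) for cytotoxicity, read by microscopy; on this read-out lower numbers stand for higher toxicity in this test and higher numbers for lower toxicity in this test:
Compound 1, `COc1cc(C#CC#Cc2cn([C@H]3C[C@H](O)[C@@H](CO)O3)c(=O)[nH]c2=O)cc(OC)c1`: in this assay compound 1 gives > 100000 nM, which is a limit of the assay and not a number.
Compound 2, `O=c1[nH]c(=O)n([C@H]2C[C@H](O)[C@@H](CO)O2)cc1C#CC#Cc1ccc([N+](=O)[O-])cc1`: in this assay compound 2 gives 100000 nM.
Compound 3, `Cc1cc(C#CC#Cc2cn([C@H]3C[C@H](O)[C@@H](CO)O3)c(=O)[nH]c2=O)ccc1F`: in this assay compound 3 gives 100000 nM.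

Compound 3 stands level with compound 2 at the digits shown, no change at the digits printed from compound 2 to compound 3 (within the scatter). Compound 1 sits at the limit of > 100000 nM in this assay, at which 1 of the 3 values shown sits. The two steps from compound 1, a number no higher from compound 1 to compound 2 (the limit leaves the size open) and a number no higher from compound 1 to compound 3 (the limit leaves the size open), leave their size open. The unmeasured compound 4, `CC(O)CC#CC#Cc1cn([C@H]2C[C@H](O)[C@@H](CO)O2)c(=O)[nH]c1=O`, differs from compound 3 thus: 2-hydroxypropyl in place of 4-fluoro-3-methylphenyl on a triple-bonded carbon. For the measured compounds named here, no measured step exchanges a phenyl group for a hydroxypropyl chain, so none bears directly; the three phenyl exchanges stayed within the scatter or at the limit. Compound 4 is therefore expected near 100000 nM, between 50000 nM and 200000 nM. The expected step is no change at the digits printed from compound 3 to compound 4 (within the scatter), with a fair chance of a limit only.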

Compound 4, minimum cytotoxic concentration: > 100000 nM
Compound 4 was reported as a limit; the forecaster's own chance of this, stated with the estimate: 50%; the middle value sits exactly at the limit.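

In this assay, the position on the triple-bonded carbon now also carries a group with no ring, 2-hydroxypropyl, and the record gives a number no lower from compound 3 to compound 4 (the limit leaves the size open) and a number no lower from compound 2 to compound 4 (the limit leaves the size open). Compound 4 gives > 100000 nM, which is a limit and not a number. So no aromatic ring is needed at this position for a value at the top of the scale: the limit of > 100000 nM in this assay, at which 2 of the 4 values shown sit.

None of the steps to compound 4 can be read for size, and the step from compound 1 cannot be read at all. From the compounds shown here alone, whether a longer chain or an amine at this position would give a measurable toxicity stays open.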